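Swapping an Ethynyl for a Trifluoromethylphenyl on a Benzoxaborole Amide

The source may report more compounds than this note shows. Statements on the series, on what has been measured and on what is new or still open speak of the compounds shown alone.

Of the compounds shown here, two sharing the same boron-containing core have been measured in a functional assay on SK-OV-3 cells (Homo sapiens) for antiproliferative activity, read by MTT assay, with a stated time of 72 h; on this read-out higher numbers stand for weaker inhibition and lower numbers for stronger inhibition. Compound 1 `O=C(CCc1cccc2c1B(O)OC2)Nc1ccc(Cl)cc1` carries a chlorine on its anilide ring and in this assay gives 5000 nM. Compound 2 `C#Cc1cccc(NC(=O)CCc2cccc3c2B(O)OC3)c1` carries an ethynyl group instead and gives 980 nM; this is the lower of the two numbers, and the gap to compound 1 lies beyond the usual scatter.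

The next compound, compound 3 `O=C(CCc1cccc2c1B(O)OC2)Nc1cccc(-c2ccc(C(F)(F)F)cc2)c1`, follows from compound 2 by one change: 4-(trifluoromethyl)phenyl in place of ethynyl on an aromatic carbon. The group enters on an aromatic carbon of a six-membered aromatic ring of carbon only, meta to a large group, at the spot the ethynyl left.

Going by the values given here, no measured pair here shows what a bulkier group at that spot does, so the direction of the step is open. Given that the small ethynyl already gave compound 2 its value of 980 nM, the expectation is that the much larger group may cost some potency, so the step of a 2.6-fold higher number from compound 2 to compound 3 (0.41 log units; beyond the scatter) is expected to point toward a weaker number. Compound 3 is estimated at 2500 nM, within a range from 600 nM to 10000 nM.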

Compound 3, half-maximal inhibitory concentration: 500 nM
Estimate against measurement, compound 3: 5.0-fold (0.70 log units) above; the whole stated range lies above it.
By their numbers in this assay, from the lowest: compounds 3 and 2 (each within the scatter of the next); then compound 1.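

In this assay, putting 4-(trifluoromethyl)phenyl in place of ethynyl gives a 2.0-fold lower number from compound 2 to compound 3 (0.29 log units; within the scatter), so the two numbers cannot be told apart on this read-out. Going by these compounds alone, this is the first sign of how much room the position has: the entering group has 10 heavy atoms and a six-membered aromatic ring, the leaving group has 2 heavy atoms and no ring, and this large increase in size on the same aromatic carbon leaves the antiproliferative read-out within its usual scatter. Nothing measured on these compounds explains why so large a change in size makes so little difference to the number.

Going by these compounds, neither group has a hydrogen-bond donor or acceptor, so it remains open how an amine or a carboxylic acid would fare at this position. On these data alone, it is also open whether a plain phenyl ring without the trifluoromethyl, or a longer chain such as a propyl group, would give a similar number, and so whether the ring, the trifluoromethyl or size alone matters here.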